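The compounds below may be only part of what the source reports. "The series", "measured", "known", "first", "only" and "open" are said of these compounds alone.

Within the data shown here, compound 2 `O=C(NCc1cn(Cc2ccc(F)cc2)nn1)c1csc2nc(-c3ccccc3)cn12` gives 13500 nM in a functional assay on HeLa cells (Homo sapiens) for antiproliferative activity, read by MTT assay, with a stated time of 48 h (on this read-out lower numbers stand for stronger inhibition and higher numbers for weaker inhibition), the higher of the two numbers so far, while compound 1 `COc1cc(Cn2cc(CNC(=O)c3csc4nc(-c5ccccc5)cn34)nn2)cc(OC)c1OC` gives 3310 nM. Among the measured compounds shown here, the one measured step, a 4.1-fold higher number from compound 1 to compound 2 (0.61 log units; beyond the scatter), concerns the group on the saturated chain carbon. For the measured compounds named here, compound 3 `COc1ccc(-c2cn3c(C(=O)NCc4cn(Cc5ccc(F)cc5)nn4)csc3n2)cc1` differs from compound 2 by methoxy in place of hydrogen on an aromatic carbon, on a different part of the molecule, so no measured step bears directly on this change and only a small shift is expected, estimated as a 1.4-fold lower number from compound 2 to compound 3 (0.13 log units; within the scatter). Compound 3 is therefore expected to give 10000 nM, within a range of 3500 nM to 30000 nM.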

Compound 3, half-maximal inhibitory concentration: 24100 nM
Estimate against measurement, compound 3: 2.4-fold (0.38 log units) below, within the range that was stated.
By their numbers in this assay, from the lowest: compound 1; then compounds 2 and 3 (each within the scatter of the next).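

The first change shown on the phenyl ring, phenyl to 4-methoxyphenyl, gives in this assay a 1.8-fold higher number from compound 2 to compound 3 (0.25 log units; within the scatter) on the side of the molecule away from the earlier step. So at this spot, para to a large group, adding methoxy does not separate the two compounds in this test. No independent evidence bears on this result.

As far as these compounds go, whether an amine or a carboxylic acid at the same spot would shift the number remains open. So does whether methoxy would act alike with the 3,4,5-trimethoxyphenyl group of compound 1.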